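Cyano for methoxycarbonyl on the chain of compound 3

A few compounds are considered here, and "the series" means these few. Any claim that something is new, unique, unknown or untested is made for them only; others in the source may bear on it.

Going by the values given here, compound 3 (`COC(=O)CCn1c(=O)c(-c2ccc(OC)cc2)cc2c(OC)cc(OC)cc21`) gives 10000 nM in a functional assay on U-87MG ATCC cells for cytotoxicity against U-87 MG (Homo sapiens), read by colorimetric assay and MTT assay (a higher number here means a weaker inhibitor, a lower number a stronger inhibitor), and stands level with compound 1 (`COc1ccc(-c2cc3c(OC)cc(OC)cc3n(CCCC#N)c2=O)cc1`) at 10000 nM and compound 2 (`COc1ccc(-c2cc3c(OC)cc(OC)cc3n(CC(=O)OCc3ccccc3)c2=O)cc1`) at 10000 nM on the numbers so far. Compound 4 (`COc1ccc(-c2cc3c(OC)cc(OC)cc3n(CCC#N)c2=O)cc1`) carries cyano in place of methoxycarbonyl on a saturated chain carbon, two bonds along the chain from an aromatic nitrogen. The nearest evidence is the measured step that exchanges a nitrile-bearing chain for the same ester-bearing chain (no change at the digits printed from compound 1 to compound 3 (within the scatter)). The two steps involving the benzyloxycarbonyl compound (no change at the digits printed from compound 1 to compound 2 (within the scatter)) and (no change at the digits printed from compound 2 to compound 3 (within the scatter)) also bear on the change. All three lie within the scatter, so the chain end has not moved the read-out in these three compounds. No step beyond the scatter is therefore expected in this assay, and the expected step is small (no change at the digits printed from compound 3 to compound 4 (within the scatter)). For compound 4 the estimated value is 10000 nM with an expected range from 5000 nM to 20000 nM in this assay series.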

Compound 4, half-maximal inhibitory concentration: 10000 nM
Compound 4: the middle estimate sits on the measured number at the digits printed; the range from low to high includes it.
By their numbers in this assay, from the lowest: compounds 1, 2, 3 and 4 (each within the scatter of the next).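

Cyano in place of methoxycarbonyl, on a saturated chain carbon, two bonds along the chain from an aromatic nitrogen, leaves this assay flat (no change at the digits printed from compound 3 to compound 4 (within the scatter)). Cyano in place of cyanomethyl at that carbon gives the same picture (no change at the digits printed from compound 1 to compound 4 (within the scatter)), as does cyanomethyl in place of benzyloxycarbonyl on the saturated chain carbon bound to an aromatic nitrogen (no change at the digits printed from compound 2 to compound 4 (within the scatter)), so the two nitrile chains and the two esters now stand level, with no spread by which to rank them. No accompanying measurement bears on this flat result.

Still open, from the compounds shown here alone, is whether any chain end moves this read-out, for example an amine, a carboxylic acid or a longer chain carrying either. Also open, going by these compounds, is whether a change on the shared core, away from this chain, would do so.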